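This account rests on a few compounds, and the source may have more. Where it says the series, first, only, none or still open, it means among the compounds named here.

For the measured compounds named here, in a functional assay on EOL1 cells (Homo sapiens) for inhibition, read by fluorescence, with a stated time of 72 h (on this read-out lower numbers stand for stronger inhibition of growth and higher numbers for weaker inhibition of growth), compound 1 `CCCCCCn1cnc2c(Nc3ccc(O)cc3)nc(N[C@H]3CC[C@H](N)CC3)nc21` gives 190 nM, the second highest of the three numbers so far. Compound 2 `CC(C)CCn1cnc2c(NCc3cccc(Cl)c3)nc(N[C@H]3CC[C@H](N)CC3)nc21` gives 1330 nM and compound 3 `CC(C)CCn1cnc2c(Nc3ccccc3)nc(N[C@H]3CC[C@H](N)CC3)nc21` gives 10 nM. Going by the values given here, the one single-change step among them, a 130-fold lower number from compound 2 to compound 3 (2.12 log units; beyond the scatter), concerns a different exchange and does not bear directly on the change followed here. Compound 4 `CCCCCCn1cnc2c(Nc3cccc(Cl)c3)nc(N[C@H]3CC[C@H](N)CC3)nc21` differs from compound 1 by 3-chlorophenyl in place of 4-hydroxyphenyl on a nitrogen on an aromatic ring. Among the compounds with values here, no measured pair shows this exchange; the only hint is that compound 3, carrying a plain phenyl on the same nitrogen, sits far lower than compound 1. A moderate drop is therefore expected, a 4.8-fold lower number from compound 1 to compound 4 (0.68 log units; beyond the scatter). Compound 4 is estimated at 40 nM, within a range from 10 nM to 200 nM.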

Compound 4, concentration for 50% growth inhibition: 310 nM
Beside the measured number, compound 4's estimate is 7.8-fold (0.89 log units) below it, outside the stated range (above it).
By their numbers in this assay, from the lowest: compound 3; then compounds 1 and 4 (each within the scatter of the next); then compound 2.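

In this assay, 3-chlorophenyl in place of 4-hydroxyphenyl on a nitrogen on an aromatic ring gives a 1.6-fold higher number from compound 1 to compound 4 (0.21 log units; within the scatter). This first direct reading of the exchange therefore separates the two groups by no real difference, although one has a hydrogen-bond donor and acceptor and the other has neither. Nothing at hand explains this result.

Still open, on these data alone, is what a plain phenyl would give on the rest of compound 1. As far as these compounds go, it is also open whether an amine or a carboxylic acid on that phenyl ring would shift the number.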